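The source may hold more compounds than are shown below. What is called first, only, known or untested is meant among the compounds shown, and "the series" means these compounds.

Measured compounds:

- compound 1, `O=C(CSc1nnnn1-c1ccccc1)N/N=c1/scc(-c2ccc(Cl)cc2)n1-c1ccccc1`, in an ADME assay on NIH3T3 cells (Mus musculus) for cytotoxicity, read by MTT assay, with a stated time of 24 h (on this read-out higher numbers stand for weaker inhibition and lower numbers for stronger inhibition), gives 313 ug/mL
- compound 2, `Cn1nnnc1SCC(=O)N/N=c1/scc(-c2ccc(Cl)cc2)n1-c1ccccc1`, in this assay gives 40 ug/mL
- compound 3, `Cn1cnnc1SCC(=O)N/N=c1/scc(-c2ccc(Cl)cc2)n1-c1ccccc1`, in this assay gives 51.7 ug/mL

Compound 1 gives the highest of the three numbers, so it is the weakest inhibitor of these cells among them. The two steps away from it both lower the number: a 7.8-fold lower number from compound 1 to compound 2 (0.89 log units; beyond the scatter) and a 6.1-fold lower number from compound 1 to compound 3 (0.78 log units; beyond the scatter), while a 1.3-fold higher number from compound 2 to compound 3 (0.11 log units; within the scatter). All of these changes sit on the sulfur-linked heteroaromatic end of the shared core.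

Compound 4, `N#Cc1ccc(-c2cs/c(=N/NC(=O)CSc3nnnn3-c3ccccc3)n2-c2ccccc2)cc1`, differs from compound 1 elsewhere: cyano in place of chloro on an aromatic carbon. Going by the values given here, no measured step touches this part of the molecule, so the two changes on the other end say nothing direct about it. With no guidance either way, the expectation is a number close to that of compound 1, with a 1.1-fold lower number from compound 1 to compound 4 (0.05 log units; within the scatter) staying within the scatter. Compound 4 is therefore estimated at 280 ug/mL, with a range from 120 ug/mL to 550 ug/mL.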

Compound 4, half-maximal inhibitory concentration: 453 ug/mL
Compound 4: the middle estimate sits 1.6-fold (0.21 log units) below what was measured, within the range that was stated.
By their numbers in this assay, from the lowest: compounds 2 and 3 (each within the scatter of the next); then compounds 1 and 4 (each within the scatter of the next).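

Going from 4-chlorophenyl to 4-cyanophenyl gives a 1.4-fold higher number from compound 1 to compound 4 (0.16 log units; within the scatter) in this assay so the two compounds cannot be told apart on this read-out. This position therefore behaves differently from the sulfur-linked end of the molecule, where a 7.8-fold lower number from compound 1 to compound 2 (0.89 log units; beyond the scatter) lies beyond the scatter and a single change clearly lowers the number. No supporting measurement accompanies this result, so nothing here explains why cyano and chloro read alike at this position.

On these data alone, the cyano group appears here only alongside the 1-phenyl-1H-tetrazol-5-yl group, so it remains open whether it would read the same with the 1-methyl-1H-tetrazol-5-yl group of compound 2. Also open, as far as these compounds go, is how an amine or a carboxylic acid in this same place on the ring would read.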